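A few compounds are considered here, and "the series" means these few. Any claim that something is new, unique, unknown or untested is made for them only; others in the source may bear on it.

Three compounds share one core and differ only in the group carried on the five-membered aromatic ring with 2 nitrogen. Compound 1 `COc1cc(/C=C/C(=O)c2cccc(-n3cc(-c4ccc(Cl)cc4)[nH]c3=O)c2)cc(OC)c1OC` bears a chlorophenyl there, and in a functional assay on SN12C cells (Homo sapiens) for inhibition (on this read-out lower numbers stand for stronger inhibition of growth and higher numbers for weaker inhibition of growth), compound 1 gives 5140 nM. Compound 2 `COc1cc(/C=C/C(=O)c2cccc(-n3cc(-c4ccccc4)[nH]c3=O)c2)cc(OC)c1OC` has hydrogen in place of chloro on an aromatic carbon, and in this assay compound 2 gives 2090 nM. Compound 3 `COc1ccc(-c2cn(-c3cccc(C(=O)/C=C/c4cc(OC)c(OC)c(OC)c4)c3)c(=O)[nH]2)cc1` has methoxy in place of chloro on an aromatic carbon, and in this assay compound 3 gives 3500 nM, the second highest of the three numbers, although both gaps to its neighbours stay within the scatter: a 1.5-fold lower number from compound 1 to compound 3 (0.17 log units; within the scatter) and a 1.7-fold higher number from compound 2 to compound 3 (0.22 log units; within the scatter). Only a 2.5-fold lower number from compound 1 to compound 2 (0.39 log units; beyond the scatter) reaches beyond the scatter.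

Compound 4 `COc1cc(/C=C/C(=O)c2cccc(-n3cc(-c4cc(OC)c(OC)c(OC)c4)[nH]c3=O)c2)cc(OC)c1OC` differs from compound 3 by 3,4,5-trimethoxyphenyl in place of 4-methoxyphenyl on an aromatic carbon, sitting on an aromatic carbon of the five-membered aromatic ring with 2 nitrogen. Among the compounds with values here, no measured step covers the addition of two further methoxy groups on this ring. The nearest precedents, a 1.5-fold lower number from compound 1 to compound 3 (0.17 log units; within the scatter) and a 1.7-fold higher number from compound 2 to compound 3 (0.22 log units; within the scatter), were both small. Compound 4 is therefore expected to show no change at the digits printed from compound 3 to compound 4 (within the scatter) in this assay, nothing beyond the scatter, and the uncertainty is wider than usual. The estimate for compound 4 in this assay is 3500 nM, within a range from 1400 nM to 9000 nM.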

Compound 4, concentration for 50% growth inhibition: 2750 nM
Estimate against measurement, compound 4: 1.3-fold (0.10 log units) above; low and high end bracket the measured number.
By their numbers in this assay, from the lowest: compounds 2, 4, 3 and 1 (each within the scatter of the next, the first and the last beyond it).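

Replacing 4-methoxyphenyl with 3,4,5-trimethoxyphenyl on this aromatic carbon raises the group from 8 to 12 heavy atoms and from 1 to 3 hydrogen-bond acceptors, yet this assay shows only a 1.3-fold lower number from compound 3 to compound 4 (0.10 log units; within the scatter), so this larger change at the position leaves no difference that can be told from the scatter. The new group also cannot be separated from either of the two groups that do differ from each other, as shown by a 1.3-fold higher number from compound 2 to compound 4 (0.12 log units; within the scatter) and by a 1.9-fold lower number from compound 1 to compound 4 (0.27 log units; within the scatter), so compound 4 sits within the scatter of both while compound 1 and compound 2 remain apart. Nothing measured here bears on why these numbers stay so close.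

Every compound shown carries a phenyl ring at this place, plain or substituted, so what an amine, a carboxylic acid or a longer alkyl chain would do there stays open. The rest of the molecule is also the same throughout, which leaves open whether these small steps would remain as small if the carbonyl of the shared core were replaced by an amide.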